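The source may report more compounds than this note shows. Statements on the series, on what has been measured and on what is new or still open speak of the compounds shown alone.

Measured so far in an ADME assay for permeability, using PAMPA, with a stated time of 4 h; a higher number here means that the compound crosses the layer faster, a lower number that the compound crosses the layer more slowly:
- compound 1 `CN1CCN(c2ccc(C(=O)Oc3ccccc3)cc2NC(=O)c2ccc(F)c([N+](=O)[O-])c2)CC1` gives 60 10^-6 cm/s
- compound 2 `Cc1c(F)c([N+](=O)[O-])cc(C(=O)Nc2cc(C(=O)Oc3ccccc3)ccc2N2CCN(C)CC2)c1Cl` gives 56.3 10^-6 cm/s
- compound 3 `Cc1c(F)c(N)cc(C(=O)Nc2cc(C(=O)OC3CCCCC3)ccc2N2CCN(C)CC2)c1Cl` gives 5.6 10^-6 cm/s

Compound 3 stands lowest of the three, well below compound 2 and compound 1. Compound 4 `Cc1c(F)c(N)cc(C(=O)Nc2cc(C(=O)Oc3ccccc3)ccc2N2CCN(C)CC2)c1Cl` differs from compound 3 by one change: phenyl in place of cyclohexyl on an oxygen next to a carbonyl group. For the measured compounds named here, no measured step shows this change by itself. Going by the values given here, the only measured step, a 1.1-fold lower number from compound 1 to compound 2 (0.03 log units; within the scatter), alters the acid-side ring and stays within the scatter, so it says little here. The values of compound 2 and compound 3 differ in two places at once, the ester group and the nitro-versus-amine group, so their gap cannot be assigned to the ester change alone. A modest rise is therefore expected, a 1.6-fold higher number from compound 3 to compound 4 (0.21 log units; within the scatter), with wide uncertainty. Compound 4 is estimated at 9 10^-6 cm/s, between 3 10^-6 cm/s and 28 10^-6 cm/s.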

Compound 4, apparent permeability: 38 10^-6 cm/s
The estimate for compound 4 lay 4.2-fold (0.63 log units) below the measured number; the measured number lies above the stated range.
By their numbers in this assay, from the lowest: compound 3; then compounds 4, 2 and 1 (each within the scatter of the next).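

In this assay, phenyl in place of cyclohexyl on an oxygen next to a carbonyl group gives a 6.8-fold higher number from compound 3 to compound 4 (0.83 log units; beyond the scatter) with nothing else altered, so this position clearly matters even though both groups have the same heavy-atom count. Amino in place of nitro on an aromatic carbon gives a 1.5-fold lower number from compound 2 to compound 4 (0.17 log units; within the scatter) and the larger ring change on a carbonyl carbon gives a 1.6-fold lower number from compound 1 to compound 4 (0.20 log units; within the scatter) and both stay within the scatter. Nothing measured here explains the gap between phenyl and cyclohexyl. As far as these compounds go, whether a methyl, a longer alkyl chain or a pyridine ring on this oxygen would match phenyl or cyclohexyl remains open.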